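The compounds below may be only part of what the source reports. "The series", "measured", "known", "first", "only" and "open" are said of these compounds alone.

Measured so far, in a functional assay on CAL-27 cells (Homo sapiens) for antiproliferative activity, read by MTT assay, with a stated time of 72 h; on this read-out higher numbers stand for weaker inhibition and lower numbers for stronger inhibition:
compound 1, `CCNC(=O)NOCc1ccc(/C=C/C(=O)NO)cc1`, 14000 nM;
compound 2, `Cc1cc(C)cc(NC(=O)NOCc2ccc(/C=C/C(=O)NO)cc2)c1`, 2270 nM;
compound 3, `COc1ccc(NC(=O)NOCc2ccc(/C=C/C(=O)NO)cc2)cc1`, 1700 nM.

Compound 1 gives the highest number of the three, so it is the weakest inhibitor among them. The unmeasured compound 4, `O=C(/C=C/c1ccc(CONC(=O)c2ccccc2)cc1)NO`, differs from compound 1 in one place: phenyl in place of ethylamino on a carbonyl carbon. Going by the values given here, no measured step alters the carbonyl carbon, so none bears on it directly; the nearest guides are the changes at the amide-type nitrogen, a 6.2-fold lower number from compound 1 to compound 2 (0.79 log units; beyond the scatter) and an 8.2-fold lower number from compound 1 to compound 3 (0.92 log units; beyond the scatter), where a ring replaced a small chain and the number fell. A ring also enters in compound 4, though here the ethylamino is lost rather than kept, so a smaller fall is expected. Compound 4 is therefore expected to show a 3.1-fold lower number from compound 1 to compound 4 (0.49 log units; beyond the scatter). The estimated value of compound 4 in this assay is 4500 nM, with a range from 1500 nM to 13000 nM.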

Compound 4, half-maximal inhibitory concentration: 2990 nM
Compound 4: the middle estimate sits 1.5-fold (0.18 log units) above what was measured; the range from low to high includes it.
By their numbers in this assay, from the lowest: compounds 3, 2 and 4 (each within the scatter of the next); then compound 1.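

In this assay, putting phenyl in place of ethylamino on the carbonyl carbon gives a 4.7-fold lower number from compound 1 to compound 4 (0.67 log units; beyond the scatter). Going by these compounds alone, this is the first change at this position, and it shows that the number can fall even when the nitrogen of ethylamino and its hydrogen-bond donor are lost. Nothing measured explains this fall. The step removes a nitrogen and adds a ring at once, so the two changes cannot be told apart. As far as these compounds go, whether cyclohexyl or benzyl on the carbonyl carbon would give a similar number remains open.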